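Replacing the cyano group of compound 1

The compounds below may be only part of what the source reports. "The series", "measured", "known", "first", "only" and "open" are said of these compounds alone.

Measured in a functional assay on KB cells (Homo sapiens) for inhibition; a lower number here means a stronger inhibitor, a higher number a weaker inhibitor:
compound 1 `N#Cc1cn(C2C=CC(CO)O2)c2ncnc(N)c12`: 176000 nM
compound 2 `N#Cc1cn([C@@H]2O[C@H](CO)[C@@H](O)[C@@H]2N)c2ncnc(N)c12`: 105000 nM

In this assay compound 1 gives 176000 nM, and compound 2 gives 105000 nM. Among the measured compounds shown here, these two values lie within the usual scatter of each other, so compound 1 stands level with the only other measured compound. Both numbers show weak inhibition.

Compound 3 `NC(=S)c1cn(C2C=CC(CO)O2)c2ncnc(N)c12` keeps the core of compound 1 but loses the cyano group: a group of 3 heavy atoms (1 carbon, 1 nitrogen, 1 sulfur; no ring) in place of a group of 2 heavy atoms (1 carbon, 1 nitrogen; no ring), on an aromatic carbon. The new group, a group of 3 heavy atoms, sits on an aromatic carbon of a five-membered aromatic ring with 1 nitrogen.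

For the measured compounds named here, no measured pair differs in one place only, so the data offer no precedent for this replacement. A moderate move toward stronger inhibition is nonetheless expected, with an estimated 2.9-fold lower number from compound 1 to compound 3 (0.47 log units; beyond the scatter), and a result within the scatter would not surprise. For compound 3 the expected value is 60000 nM, with an estimated range of 12000 nM to 200000 nM.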

Compound 3, half-maximal inhibitory concentration: 5000 nM
The estimate for compound 3 lay 12-fold (1.08 log units) above the measured number; the measured number lies below the stated range.
By their numbers in this assay, from the lowest: compound 3; then compounds 2 and 1 (each within the scatter of the next).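

In this assay, putting the group of 3 heavy atoms (1 carbon, 1 nitrogen, 1 sulfur) in place of the cyano group gives a 35-fold lower number from compound 1 to compound 3 (1.55 log units; beyond the scatter), so a change at this aromatic carbon of the five-membered aromatic ring can shift the read-out well beyond the scatter. The earlier compounds shown here offered no step at this position, and this one shows that the position is sensitive to what it carries, with the entering group counting 1 hydrogen-bond donor where the cyano group counts none. Nothing measured here accounts for the size of this step.

As far as these compounds go, it stays open whether the sulfur atom, the hydrogen-bond donor or the whole group matters, and a carboxamide, an amidine or a carboxylic acid on the same carbon would help to separate these. From the compounds shown here alone, it also stays open whether the same replacement would give a similar step on compound 2.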